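A few compounds are considered here, and "the series" means these few. Any claim that something is new, unique, unknown or untested is made for them only; others in the source may bear on it.

Measured so far:
compound 1 `O=C(Cn1c(=O)oc2cc(Cl)ccc21)Nc1nc2ccccc2s1` — 52.5%
compound 2 `O=C(Cn1c(=O)oc2ccccc21)Nc1nc2ccc([N+](=O)[O-])cc2s1` — 19.2%

Both numbers come from an ADME assay on RAW264.7 cells (Mus musculus) for cytotoxicity, read by MTT assay, with a stated time of 72 h, tested at 100 uM; on this read-out lower numbers stand for a weaker effect and higher numbers for a stronger effect at the one concentration tested. Within the data shown here, of the two, compound 2 stands lowest; its only neighbour is compound 1, whose number is higher by an amount beyond the usual scatter of repeated measurements. Compound 3 `O=C(Cn1c(=O)oc2cc(Cl)ccc21)Nc1nc2ccc([N+](=O)[O-])cc2s1` has not yet been measured. It differs from compound 2 in a single place: chloro in place of hydrogen on an aromatic carbon. The chloro enters on an aromatic carbon of a six-membered aromatic ring of carbon only, part of a fused system of two rings. Among the measured compounds shown here, no measured pair shows this change by itself, so its size cannot be read from the numbers at hand. Compound 1 carries a chloro on the same ring, but it also differs from compound 2 in a second place, so its higher value can only be noted, not traced to the chloro. The step from compound 2 to compound 3 is expected to be modest and upward, a number 12.8 percentage points higher from compound 2 to compound 3 (beyond the scatter). Compound 3 is therefore estimated at 32%, within a range from 12% to 55%.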

Compound 3, a percentage reported as inhibition, at one concentration (the size of the read-out at that concentration, not a potency): 14.2%
Beside the measured number, compound 3's estimate is 17.8 percentage points above it; the measured number falls inside the stated range.
By their numbers in this assay, from the lowest: compounds 3 and 2 (each within the scatter of the next); then compound 1.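

In this assay chloro in place of hydrogen on an aromatic carbon gives a number 5 percentage points lower from compound 2 to compound 3 (within the scatter) so with the nitro present, compound 2 and compound 3 cannot be told apart at this position, para to a fused ring and meta to a fused ring. The nitro step, by contrast, is large: with the chloro held in place, adding the nitro gives a number 38.3 percentage points lower from compound 1 to compound 3 (beyond the scatter) and this single change separates two compounds clearly in this series. No measured evidence on the reason for either step is at hand.

None of the compounds shown lacks both the chloro and the nitro, so what the chloro does without the nitro, and what the nitro does without the chloro, remain open. From the compounds shown here alone, it is also open whether another group at the chloro's position, such as an amine or a carboxylic acid, would likewise leave the number within the scatter of compound 2 or move it clearly away.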